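The source may hold more compounds than are shown below. What is called first, only, known or untested is meant among the compounds shown, and "the series" means these compounds.

Working notes on the series. In a functional assay on cells (Cancer cell lines, Homo sapiens) for cytotoxicity, read by sulforhodamine B assay, with a stated time of 48 h (a lower number here means a stronger inhibitor of growth, a higher number a weaker inhibitor of growth), compound 1 `O=C1N=C(N2N=C(c3ccccc3)CC2c2ccccc2O)S/C1=C1/C(=O)Nc2ccccc21` gives 2070 nM, and compound 2 `O=C1N=C(N2N=C(c3ccccc3)CC2c2ccccc2O)S/C1=C1/C(=O)Nc2ccc(Br)cc21` gives 230 nM. Among the compounds with values here, compound 1 thus stands at the higher of the two numbers measured so far; the only measured step, a 9.0-fold lower number from compound 1 to compound 2 (0.95 log units; beyond the scatter), sits on the aromatic carbon of the fused part of the shared core and not on the saturated ring carbon considered here.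

Compound 3 `COc1ccc(C2CC(c3ccccc3)=NN2C2=NC(=O)/C(=C3\C(=O)Nc4ccccc43)S2)cc1` differs from compound 1 by 4-methoxyphenyl in place of 2-hydroxyphenyl on a saturated ring carbon. Within the data shown here, no measured pair changes this group, so the step from compound 1 to compound 2 bears on the present question only as a scale of what a single substitution has done; it gives no direction for this change. With nothing in the measured data pointing either way, the expected step of a 1.0-fold lower number from compound 1 to compound 3 (0.01 log units; within the scatter) is one of no change beyond the scatter, and the range must be kept wide to cover a shift in either direction. Compound 3 is therefore expected to give about 2000 nM in this assay, with a range from 600 nM to 7000 nM.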

Compound 3, concentration for 50% growth inhibition: 2010 nM
Compound 3: middle estimate off by 1.0-fold (0.00 log units), on the low side, and the stated range covers the measured number.
By their numbers in this assay, from the lowest: compound 2; then compounds 3 and 1 (each within the scatter of the next).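

In this assay, a 1.0-fold lower number from compound 1 to compound 3 (0.01 log units; within the scatter) shows that this saturated ring carbon tolerates the exchange of 2-hydroxyphenyl for 4-methoxyphenyl with no change beyond the scatter, something the bromo step on the core could not show. The exchange takes the aryl group from 1 hydrogen-bond donor to 0 hydrogen-bond donors and moves its oxygen-bearing substituent to a different ring carbon, so the two compounds show that a hydrogen-bond donor on this aryl group is not required to hold the number in this assay, at least when 4-methoxyphenyl stands in its place. Within the data shown here, no supporting measurement is available to explain this result, and the single pair cannot separate the contribution of the hydroxy-to-methoxy exchange from that of the altered substitution site on the aryl ring.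

Still open, going by these compounds, is whether the number at this carbon responds to any aryl group at all, for example an unsubstituted phenyl or an aryl ring carrying an amine or a carboxylic acid. Also open, on these data alone, is whether the bromo gain seen in a 9.0-fold lower number from compound 1 to compound 2 (0.95 log units; beyond the scatter) carries over to the 4-methoxyphenyl compound.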